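Isopentyloxy in place of fluoro: a step within scatter?

The compounds below may be only part of what the source reports. "The series", "measured", "known", "first", "only" and "open" are said of these compounds alone.

In a functional assay on A549 cells (Homo sapiens) for cytotoxicity, with a stated time of 48 h (a lower number here means a stronger inhibitor, a higher number a weaker inhibitor), compound 1 `CCOc1ccc2oc(/C=C/[S+](C)[O-])cc(=O)c2c1` gives 1500 nM, compound 2 `CCCCCOc1ccc2oc(/C=C/[S+](C)[O-])cc(=O)c2c1` gives 1600 nM and compound 3 `C[S+]([O-])/C=C/c1cc(=O)c2cc(F)ccc2o1` gives 2100 nM. Compound 3 therefore stands within the scatter of both other compounds, and the three values show no order.

Compound 4 `CC(C)CCOc1ccc2oc(/C=C/[S+](C)[O-])cc(=O)c2c1` has isopentyloxy in place of fluoro on an aromatic carbon. Two measured steps exchange an alkoxy group and fluoro at this place, in the opposite sense: a 1.4-fold higher number from compound 1 to compound 3 (0.15 log units; within the scatter) for fluoro in place of ethoxy, and a 1.3-fold higher number from compound 2 to compound 3 (0.12 log units; within the scatter) for fluoro in place of pentyloxy. Both lie within the scatter. Changing the chain itself also gave a step within the scatter, a 1.1-fold higher number from compound 1 to compound 2 (0.03 log units; within the scatter). Isopentyloxy has not been measured in this series, so its own contribution remains untested.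

No change beyond the scatter is expected in this assay. The expected step is a 1.3-fold lower number from compound 3 to compound 4 (0.12 log units; within the scatter). Compound 4 is estimated at 1600 nM, with an expected range of 800 nM to 3000 nM.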

Compound 4, half-maximal inhibitory concentration: 1000 nM
Estimate against measurement, compound 4: 1.6-fold (0.20 log units) above; the measured number falls inside the stated range.
By their numbers in this assay, from the lowest: compounds 4, 1, 2 and 3 (each within the scatter of the next, the first and the last beyond it).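

In this assay, going by these compounds alone, the exchange of fluoro for isopentyloxy on this aromatic carbon gives a 2.1-fold lower number from compound 3 to compound 4 (0.32 log units; beyond the scatter) and is the first step to pass the scatter, though only modestly. The chain alone does not resolve the alkoxy compounds: the branched isopentyloxy chain gives a 1.6-fold lower number from compound 2 to compound 4 (0.20 log units; within the scatter) against pentyloxy and a 1.5-fold lower number from compound 1 to compound 4 (0.18 log units; within the scatter) against ethoxy, so the only separation lies between the two ends of the order, and neither ethoxy nor pentyloxy is separated from fluoro. No supporting measurement bears on the reason for this step.

Open, as far as these compounds go, is whether a longer chain such as octyloxy, or a chain ending in an amine, at this place would move the number beyond the scatter of compound 4. A hydroxy group or plain hydrogen at this place also remains to be placed against fluoro and the alkoxy groups.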